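The source may hold more compounds than are shown below. What is called first, only, known or untested is meant among the compounds shown, and "the series" means these compounds.

Measured so far:
- compound 1, `O=C(N/N=C/c1ccc(F)cc1)c1cccnc1Nc1cccc(C(F)(F)F)c1`: 41.2%
- compound 2, `O=C(N/N=C/c1ccc(O)cc1)c1cccnc1Nc1cccc(C(F)(F)F)c1`: 68%
- compound 3, `O=C(N/N=C/c1ccc(O)c(O)c1)c1cccnc1Nc1cccc(C(F)(F)F)c1`: 46.9%

These three share one core and differ only in the ring that hangs from the carbon double-bonded to nitrogen. In a functional assay on the whole organism (strain Wistar) for inhibition, with Rattus norvegicus as the target, read by paw edema, with a stated time of 2 h, at a dose of 10 mg/kg by the intraperitoneal route (on this read-out lower numbers stand for less inhibition and higher numbers for more inhibition at the one dose given (going by the name of the read-out)), compound 3 gives 46.9%, the second highest of the three numbers; it sits within the scatter of compound 1, as a number 5.7 percentage points higher from compound 1 to compound 3 (within the scatter) shows, and well apart from compound 2, as a number 21.1 percentage points lower from compound 2 to compound 3 (beyond the scatter) shows. Compound 4, `COc1ccc(/C=N/NC(=O)c2cccnc2Nc2cccc(C(F)(F)F)c2)cc1OC`, has not yet been measured. It differs from compound 3 in one place: 3,4-dimethoxyphenyl in place of 3,4-dihydroxyphenyl on a carbon with a double bond to nitrogen.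

For the measured compounds named here, two measured steps bear on this change. Putting a hydroxy on the ring raised the number, a number 26.8 percentage points higher from compound 1 to compound 2 (beyond the scatter), while a second hydroxy lowered it again, a number 21.1 percentage points lower from compound 2 to compound 3 (beyond the scatter). Compound 4 keeps both oxygens but carries no hydrogen-bond donors on that ring, as compound 1 carries none; the numbers do not show what capping both hydroxys does. Compound 4 is therefore expected to land near compounds 1 and 3, with a step of a number 4.9 percentage points lower from compound 3 to compound 4 (within the scatter) that stays within the scatter. Compound 4 is estimated at 42%, with a range from 30% to 56%.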

Compound 4, a percentage reported as inhibition, in the whole organism at one dose (the size of the read-out at that dose, not a potency): 49%
Compound 4: the middle estimate sits 7 percentage points below what was measured; the range from low to high includes it.
By their numbers in this assay, from the lowest: compounds 1, 3 and 4 (each within the scatter of the next); then compound 2.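

In this assay, replacing both hydroxys with methoxys gives a number 2.1 percentage points higher from compound 3 to compound 4 (within the scatter) and so leaves the number in place, even though the hydrogen-bond donors of this ring are gone. Compared with the fluoro ring, which also has no such donors, 3,4-dimethoxyphenyl gives a number 7.8 percentage points higher from compound 1 to compound 4 (within the scatter) and cannot be told apart from it either. Compound 2 alone stands apart, with a number 19 percentage points lower from compound 2 to compound 4 (beyond the scatter) as its step to the dimethoxy ring, so the higher number seen with 4-hydroxyphenyl does not return with two oxygens on the ring, whether these carry hydrogen or methyl.

No measured evidence explains this pattern. From the compounds shown here alone, whether 4-methoxyphenyl would match compound 2, and what a ring bearing an amine or a carboxylic acid would give, remains open.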